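Benzyl to Phenyl on the Lactam Nitrogen

A few compounds are considered here, and "the series" means these few. Any claim that something is new, unique, unknown or untested is made for them only; others in the source may bear on it.

Compounds measured so far:
Compound 1, `COc1cccc(OC)c1C1SCC(=O)N1Cc1ccc(OC(F)(F)F)cc1`: 155 nM
Compound 2, `COc1cc(OC)c(C2CCCCN2Cc2ccc(OC(F)(F)F)cc2)c(OC)c1`: 1590 nM
Compound 3, `COc1cccc(OC)c1C1CCCC(=O)N1Cc1ccccc1`: 2420 nM

In a functional assay on CHO cells for antagonist activity at Orexin/Hypocretin receptor type 1 (Homo sapiens), read by FLIPR and calcium flux (a higher number here means a weaker inhibitor, a lower number a stronger inhibitor), compound 3 gives 2420 nM, the highest of the three numbers. Its nearest neighbour is compound 2, whose value in this assay is 1590 nM, a gap that lies within the scatter, so the two are not distinguished. Compound 1, which in this assay gives 155 nM, stands well apart from compound 3, a gap beyond the scatter.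

The not yet measured compound 4, `COc1cccc(OC)c1C1CCCC(=O)N1c1ccccc1`, differs from compound 3 in one place: phenyl in place of benzyl on an amide-type nitrogen in a ring. Within the data shown here, no measured pair shows this change, so its effect is not known from the data at hand. The account expects the step of a 2.5-fold higher number from compound 3 to compound 4 (0.39 log units; beyond the scatter) to go toward a higher number, a modest step that may reach beyond the scatter. For compound 4 the estimated value in this assay is 6000 nM, with a range from 2000 nM to 20000 nM.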

Compound 4, half-maximal inhibitory concentration: > 10000 nM
Compound 4: no number, only a limit (the forecaster's own chance of this, stated with the estimate: 30%); middle value at least 1.6-fold (0.22 log units) away from the limit.
By their numbers in this assay, from the lowest: compound 1; then compounds 2 and 3 (each within the scatter of the next). At a limit, above all of these: compound 4.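

In this assay compound 4 gives > 10000 nM, which is a limit of the assay and not a number. Phenyl in place of benzyl on the amide-type nitrogen in a ring gives an at least 4.1-fold higher number from compound 3 to compound 4 (0.61 log units; beyond the scatter); this is the first one-place step among these compounds, and it shows that this position responds to the change, toward a weaker inhibitor. How far the step reaches stays unknown because compound 4 sits at a limit: the limit of > 10000 nM in this assay, at which 1 of the 4 values shown sits.

The compounds shown leave open whether a longer chain on this nitrogen, such as phenethyl, would move the number the other way. They also leave open whether a carboxylic acid or an amine on the benzyl ring of compound 3 would change its value.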